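Fluoro in place of chloro on the shared core

The source may hold more compounds than are shown below. What is called first, only, known or untested is meant among the compounds shown, and "the series" means these compounds.

compound 1 `O=c1c(C2N=C(c3ccccc3)SS2)coc2ccc(Cl)cc12`: 74900 nM
compound 2 `O=c1c(C2N=C(c3ccccc3)SS2)coc2cc(Cl)c(Cl)cc12`: 98000 nM
compound 3 `O=c1c(C(=S)Nc2ccccc2)coc2ccccc12`: a limit, > 100000 nM

In a functional assay on HEp-2 cells (Homo sapiens) for inhibition, read by sulforhodamine B assay, with a stated time of 48 h (a lower number here means a stronger inhibitor, a higher number a weaker inhibitor), compound 2 gives 98000 nM and compound 1 gives 74900 nM; the two sit within the scatter of each other, so neither is set apart. Compound 3 reaches only the limit of the limit of > 100000 nM in this assay, at which 1 of the 3 values shown sits. Within the data shown here, the one measured step on this ring, a 1.3-fold higher number from compound 1 to compound 2 (0.12 log units; within the scatter), adds a chloro group and stays within the scatter. Compound 4 `O=c1c(C2N=C(c3ccccc3)SS2)coc2cc(Cl)c(F)cc12` differs from compound 2 by fluoro in place of chloro on an aromatic carbon. Among the measured compounds shown here, only that chloro step bears on this change, and it was small, so no step beyond the scatter is expected in this assay: a 1.1-fold lower number from compound 2 to compound 4 (0.04 log units; within the scatter) is the estimated step. Compound 4 is expected to give 90000 nM, between 40000 nM and 200000 nM.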

Compound 4, half-maximal inhibitory concentration: 97600 nM
Estimate against measurement, compound 4: 1.1-fold (0.04 log units) below; the range from low to high includes it.
By their numbers in this assay, from the lowest: compounds 1, 4 and 2 (each within the scatter of the next). At a limit, above all of these: compound 3.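

Among these compounds, the earlier chloro step sat on a different aromatic carbon, so this is the first reading at this one, ortho to a chloro group and para to a fused ring. In this assay, fluoro in place of chloro here gives a 1.0-fold lower number from compound 2 to compound 4 (0.00 log units; within the scatter), so the two halogens are not told apart at this carbon. Nothing in the data gives a cause for this step.

Open, on these data alone, is whether a group other than a halogen at this carbon, such as an amine, a methoxy group or a carboxylic acid, would give a number outside the scatter of compound 2.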